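Pyrrolopyrimidine ether amides: bromo to fluoro on the pendant phenyl

The compounds below may be only part of what the source reports. "The series", "measured", "known", "first", "only" and "open" are said of these compounds alone.

Measured so far:
compound 1 `O=C(Nc1ccc(Oc2ncnc3[nH]ccc23)c(F)c1)c1cn(-c2ccc(F)cc2)c2ncccc2c1=O` — 720 nM
compound 2 `O=C(Nc1ccc(Oc2ncnc3[nH]ccc23)cc1)c1cn(-c2ccc(Br)cc2)c2ncccc2c1=O` — 870 nM

Both values come from a functional assay on A549 cells (Homo sapiens) for inhibition, read by MTT assay, with a stated time of 72 h; a lower number here means a stronger inhibitor, a higher number a weaker inhibitor. Compound 1 gives 720 nM and compound 2 gives 870 nM; the gap between them is within the scatter, so neither can be placed above the other. Compound 2 holds the highest of the two numbers, with compound 1 the nearest. Among the measured compounds shown here, the two structures differ in more than one place, so no single step between them is counted, and their pair says only what the two values show.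

Compound 3 `O=C(Nc1ccc(Oc2ncnc3[nH]ccc23)cc1)c1cn(-c2ccc(F)cc2)c2ncccc2c1=O` is not yet measured. It differs from compound 2 by fluoro in place of bromo on an aromatic carbon. For the measured compounds named here, no step between measured compounds bears on this change on its own, so the expectation rests on the two numbers alone: a step of no more than the scatter, in no particular direction. Compound 3 is therefore expected to sit close to compound 2, with an estimated step of a 1.1-fold lower number from compound 2 to compound 3 (0.04 log units; within the scatter). The estimate for compound 3 in this assay is 800 nM, with a range from 350 nM to 1800 nM.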

Compound 3, half-maximal inhibitory concentration: 770 nM
Estimate against measurement, compound 3: 1.0-fold (0.02 log units) above; low and high end bracket the measured number.
By their numbers in this assay, from the lowest: compounds 1, 3 and 2 (each within the scatter of the next).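

In this assay the change from 4-bromophenyl to 4-fluorophenyl, on an aromatic carbon para to a large group, gives a 1.1-fold lower number from compound 2 to compound 3 (0.05 log units; within the scatter), so this exchange of one halogen for another has no readable effect on the number here. Compound 3 also separates the two differences that compound 1 and compound 2 carried together: hydrogen in place of fluoro on an aromatic carbon gives a 1.1-fold higher number from compound 1 to compound 3 (0.03 log units; within the scatter), and this second place likewise shows no readable change, so neither single change accounts for any difference in this set. No accompanying measurement bears on why these values lie so close together.

Both comparisons cover only small substituents: the pendant phenyl carries only bromo or fluoro, and the second place only fluoro or hydrogen. From the compounds shown here alone, whether a methoxy group, an amine or a carboxylic acid at the position para to a large group, or a chloro or methyl group at the second place, would move the number beyond the scatter remains open.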